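Methyl in place of methylsulfanyl on the core of compound 2

This account rests on a few compounds, and the source may have more. Where it says the series, first, only, none or still open, it means among the compounds named here.

Measured so far in a functional assay on the whole organism for inhibition, with Digitaria ciliaris as the target, with a stated time of 72 h, tested at 10 mg/L; on this read-out lower numbers stand for less inhibition of growth and higher numbers for more inhibition of growth at the one concentration tested:
compound 1 `COc1cc(C)nc2n/c(=N/C(=O)c3c(-c4ccc(Cl)cc4Cl)noc3C)sn12` gives 50.3%
compound 2 `COc1cc(SC)nc(NC(=S)NC(=O)c2c(-c3ccc(Cl)cc3Cl)noc2C)n1` gives 34.8%
compound 3 `COc1cc(SC)nc2n/c(=N/C(=O)c3c(-c4ccc(Cl)cc4Cl)noc3C)sn12` gives 19.8%

Compound 2 stands second of the three numbers, beyond the scatter from compound 1 above it and from compound 3 below it. Compound 4 `COc1cc(C)nc(NC(=S)NC(=O)c2c(-c3ccc(Cl)cc3Cl)noc2C)n1` is not yet measured; it differs from compound 2 by methyl in place of methylsulfanyl on an aromatic carbon. Among the compounds with values here, one measured step bears on this change, run the other way on the core of compound 1: a number 30.5 percentage points lower from compound 1 to compound 3 (beyond the scatter). Read in reverse on the core of compound 2, a rise of roughly that size is expected, a number 25.2 percentage points higher from compound 2 to compound 4 (beyond the scatter). Compound 4 is therefore estimated to give 60% in this assay, with a range from 40% to 80%.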

Compound 4, percent growth inhibition at one concentration: 30.2%
Compound 4: middle estimate off by 29.8 percentage points, on the high side, outside the stated range (below it).
By their numbers in this assay, from the lowest: compound 3; then compounds 4 and 2 (each within the scatter of the next); then compound 1.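

In this assay, methyl in place of methylsulfanyl on the core of compound 2 reads as a number 4.6 percentage points lower from compound 2 to compound 4 (within the scatter). At this position the change therefore carries no fixed size from one core to the other, and the large step seen on the core of compound 1 is no general rule: the same change on two cores in this assay, a number 30.5 percentage points lower (beyond the scatter) from compound 1 to compound 3 and a number 4.6 percentage points higher (within the scatter) from compound 4 to compound 2, 35.1 percentage points apart, beyond the scatter of two such steps

Open, going by these compounds, is whether an amine or a longer chain such as ethylsulfanyl at this position would separate from methyl and methylsulfanyl on either core. With one pair per core, the compounds shown do not tell which part of the core sets the gap.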